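The source may report more compounds than this note shows. Statements on the series, on what has been measured and on what is new or still open speak of the compounds shown alone.

Measured so far in a functional assay for inhibition, with Homo sapiens as the target; on this read-out lower numbers stand for tighter binding and higher numbers for weaker binding:
compound 1 `N#Cc1ccccc1C1OCC(C/C=C\CCC(=O)O)C(c2cccnc2)O1` gives 245 nM
compound 2 `O=C(O)CC/C=C\CC1COC(c2cccnc2)OC1c1cccnc1` gives 759 nM
compound 3 `CC(C)(Oc1ccc(F)cc1)C1OCC(C/C=C\CCC(=O)O)C(c2cccnc2)O1` gives 120 nM

Compound 3 holds the lowest of the three numbers in this assay. Compound 1 stands nearest to it and compound 2 furthest, and both gaps lie beyond the scatter, so compound 3 is the tightest binder among the three measured compounds. For the measured compounds named here, the only step between compounds that differ in one place is a 3.1-fold higher number from compound 1 to compound 2 (0.49 log units; beyond the scatter); it concerns the group on a saturated ring carbon and says nothing about the chain carbon that carries the group varied next.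

Compound 4 `CC(C)(Sc1ccccc1)C1OCC(C/C=C\CCC(=O)O)C(c2cccnc2)O1` differs from compound 3 by phenylsulfanyl in place of 4-fluorophenoxy on a saturated chain carbon bound to two saturated chain carbons and a saturated ring carbon. Going by the values given here, no measured step bears on this change: the group at this chain carbon is varied nowhere else among the three compounds, and compound 2, which lacks such a group altogether, differs from compound 3 in more than one place. With nothing in the series to set the direction, the working expectation is a step that stays within the scatter, a 1.1-fold higher number from compound 3 to compound 4 (0.03 log units; within the scatter), and the range is kept wide in both directions for compound 4. Compound 4 is therefore estimated at 130 nM, between 45 nM and 380 nM in this assay.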

Compound 4, dissociation constant: 200 nM
Compound 4: middle estimate off by 1.5-fold (0.19 log units), on the low side; the measured number falls inside the stated range.
By their numbers in this assay, from the lowest: compounds 3, 4 and 1 (each within the scatter of the next, the first and the last beyond it); then compound 2.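

In this assay, the change from 4-fluorophenoxy to phenylsulfanyl on a saturated chain carbon bound to two saturated chain carbons and a saturated ring carbon gives a 1.7-fold higher number from compound 3 to compound 4 (0.22 log units; within the scatter); this first reading at the position does not tell the two groups apart. Taken as a whole, the group of 10 heavy atoms that carries phenylsulfanyl separates from pyridin-3-yl on the saturated ring carbon, with a 3.8-fold lower number from compound 2 to compound 4 (0.58 log units; beyond the scatter), but not from the group of 8 heavy atoms that is 2-cyanophenyl, with a 1.2-fold lower number from compound 1 to compound 4 (0.09 log units; within the scatter). No supporting measurement bears on these results.

The step to compound 4 swaps oxygen for sulfur and removes the fluorine together, so the compounds shown cannot divide it between those two changes; an unsubstituted phenoxy or a 4-fluorophenylsulfanyl group on this chain carbon would separate them. Also open, going by these compounds, is how the read-out responds to an amide in place of the carboxylic acid that all four compounds carry.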